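A few compounds are considered here, and "the series" means these few. Any claim that something is new, unique, unknown or untested is made for them only; others in the source may bear on it.

Three compounds share one core and differ only in the group on the oxygen next to the carbonyl group of the carbamate. Compound 1 `Cc1nc(S(C)(=O)=O)ccc1Oc1ncnc(OC2CCN(C(=O)OC(C)(C)C#N)CC2)c1F` gives 92.9 nM in a functional assay on isolated protein for inhibition of Glucose-dependent insulinotropic receptor (Homo sapiens), read by HTRF and cAMP accumulation; a higher number here means that more compound is needed for the effect, a lower number that less compound is needed. Compound 2 `Cc1nc(S(C)(=O)=O)ccc1Oc1ncnc(OC2CCN(C(=O)OC(C)(C)CF)CC2)c1F` gives 19.9 nM, and compound 3 `Cc1nc(S(C)(=O)=O)ccc1Oc1ncnc(OC2CCN(C(=O)O[C@H](C)CF)CC2)c1F` gives 196 nM, the highest of the three numbers. The steps are a 4.7-fold lower number from compound 1 to compound 2 (0.67 log units; beyond the scatter), a 2.1-fold higher number from compound 1 to compound 3 (0.32 log units; beyond the scatter) and a 9.8-fold higher number from compound 2 to compound 3 (0.99 log units; beyond the scatter).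

Compound 4 `Cc1nc(S(C)(=O)=O)ccc1Oc1ncnc(OC2CCN(C(=O)O[C@@H](C)C(F)(F)F)CC2)c1F` is made from compound 3 by one change: 1-(trifluoromethyl)ethyl in place of 1-(fluoromethyl)ethyl on an oxygen next to a carbonyl group. Among the measured compounds shown here, no measured pair swaps a fluoromethyl for a trifluoromethyl, so the expectation rests on how much this position has already moved the numbers. The change from cyano to fluoromethyl gave a 4.7-fold lower number from compound 1 to compound 2 (0.67 log units; beyond the scatter), and losing a methyl gave a 9.8-fold higher number from compound 2 to compound 3 (0.99 log units; beyond the scatter), so this position is sensitive, but the direction of adding two fluorines is not shown. A modest step in either direction is plausible; compound 4 is therefore expected to give 130 nM, with a range from 40 nM to 400 nM. This estimate means a step of a 1.5-fold lower number from compound 3 to compound 4 (0.18 log units; within the scatter) from compound 3, expected to fall near the scatter.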

Compound 4, half-maximal effective concentration: 9.86 nM
Compound 4: middle estimate off by 13-fold (1.12 log units), on the high side; measured number below the stated range.
By their numbers in this assay, from the lowest: compounds 4 and 2 (each within the scatter of the next); then compound 1; then compound 3.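

Replacing the 1-(fluoromethyl)ethyl group with 1-(trifluoromethyl)ethyl gives a 20-fold lower number from compound 3 to compound 4 (1.30 log units; beyond the scatter) in this assay, the largest step yet seen at this position, so the number of fluorines on this small chain matters a great deal. The step of a 2.0-fold lower number from compound 2 to compound 4 (0.30 log units; within the scatter) cannot be told apart from repeat scatter, so a group without the second methyl can read as low as the 1-(fluoromethyl)-1-methylethyl group. The nitrile-bearing group also falls well behind, with a 9.4-fold lower number from compound 1 to compound 4 (0.97 log units; beyond the scatter) on moving to 1-(trifluoromethyl)ethyl.

Nothing available explains why the two added fluorines have so large an effect. The compounds shown also leave open how a 1-(difluoromethyl)ethyl group, which would sit between the two fluorine counts, or a longer chain such as 1-(trifluoromethyl)propyl would read at this position.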